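Compound 2 to compound 3: fluoro in place of hydrogen

A few compounds are considered here, and "the series" means these few. Any claim that something is new, unique, unknown or untested is made for them only; others in the source may bear on it.

In a functional assay on PBMC cells (Homo sapiens) for inhibition, read by HTRF, with stated times of 15 min and 24 h (on this read-out lower numbers stand for stronger inhibition and higher numbers for weaker inhibition), compound 1 (`O=C(Nc1ccc2c(c1)B(O)OC2)c1ccccc1C(F)(F)F`) gives 2100 nM. Compound 2 (`O=C(Nc1ccc2c(c1)B(O)OC2)c1ccccc1`) gives > 100000 nM, which is a limit of the assay and not a number. Compound 3 (`O=C(Nc1ccc2c(c1)B(O)OC2)c1ccccc1F`) departs from compound 2 by a single change: fluoro in place of hydrogen on an aromatic carbon. Among the compounds with values here, one measured step bears on this change: an at least 47-fold higher number from compound 1 to compound 2 (1.67 log units; beyond the scatter), a large step beyond the scatter, with hydrogen in place of trifluoromethyl on an aromatic carbon. Compound 3 instead puts fluoro in place of hydrogen, so a step towards a lower number is expected in this assay. Only part of the distance back towards compound 1 at 2100 nM is expected, since fluoro is not trifluoromethyl. The expected change is an at least 4.0-fold lower number from compound 2 to compound 3 (0.60 log units; beyond the scatter). For compound 3 the estimated value is 25000 nM, with an expected range from 6000 nM to 100000 nM.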

Compound 3, half-maximal inhibitory concentration: > 10000 nM
Compound 3 ended at the assay's limit (the forecaster's own chance of this, stated with the estimate: 35%); the middle value does not contradict the limit.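

In this assay, trifluoromethyl and fluoro on this aromatic carbon, ortho to a large group, do not give the same result, with an at least 4.7-fold higher number from compound 1 to compound 3 (0.67 log units; beyond the scatter), so a single fluorine does not reproduce what trifluoromethyl gives here. Compound 3 gives > 10000 nM, which is a limit of the assay and not a number. The step between compound 2 and compound 3 cannot be read, because both compounds end at limits, and whether fluoro does anything at all compared with hydrogen stays unsettled: the limit of > 10000 nM in this assay, at which 1 of the 3 values shown sits.

The compounds shown leave open whether the stronger inhibition of compound 1 belongs to trifluoromethyl alone or would also appear with a chloro, methyl or methoxy group at this place. They also leave open how fluoro and hydrogen rank against each other in this assay, for which a number on each compound would be needed.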